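The source may report more compounds than this note shows. Statements on the series, on what has been measured and on what is new or still open speak of the compounds shown alone.

Measured compounds in a functional assay on HepG2 cells (Homo sapiens) for antiproliferative activity, read by MTT assay, with a stated time of 48 h; on this read-out lower numbers stand for stronger inhibition and higher numbers for weaker inhibition:

Compound 1, `COc1ccc(-n2nncc2CN2C(=O)C3(C(C#N)=C(N)Oc4c3c3nc5ccccc5nc3c3ccccc43)c3ccccc32)cc1`, gives > 50000 nM, which is a limit of the assay and not a number.
Compound 2, `CCOc1ccc(-n2nncc2CN2C(=O)C3(C(C#N)=C(N)Oc4c3c3nc5ccccc5nc3c3ccccc43)c3ccccc32)cc1`, gives > 50000 nM, again a limit of the assay.
Compound 3, `N#CC1=C(N)Oc2c(c3nc4ccccc4nc3c3ccccc23)C12C(=O)N(Cc1cnnn1-c1ccc(S(N)(=O)=O)cc1)c1ccccc12`, gives 42200 nM.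

Compound 1 therefore stands at the edge of what this assay can report, and the limit of > 50000 nM in this assay, at which 2 of the 3 values shown sit, shows that most of the values known here sit at that same limit. Every compound shares one core and differs only in the group carried on the aromatic nitrogen of the five-membered ring.

Compound 4, `N#CC1=C(N)Oc2c(c3nc4ccccc4nc3c3ccccc23)C12C(=O)N(Cc1cnnn1-c1ccc(Cl)c(Cl)c1)c1ccccc12`, differs from compound 1 in one place: 3,4-dichlorophenyl in place of 4-methoxyphenyl on an aromatic nitrogen.

For the measured compounds named here, no measured step touches a 3,4-dichlorophenyl. The step that the two limits leave unreadable from compound 1 to compound 2, and the step of an at least 1.1-fold lower number from compound 1 to compound 3 (0.07 log units; that floor lies within the scatter), whose floor lies within the scatter. The step of an at least 1.1-fold lower number from compound 2 to compound 3 (0.07 log units; that floor lies within the scatter). Nothing among these points to a change beyond the scatter for any group tried on this position.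

For compound 4 the expected step is therefore an at least 1.1-fold lower number from compound 1 to compound 4 (0.04 log units; that floor lies within the scatter), none beyond the scatter. Compound 4 is estimated at 45000 nM, with a range from 20000 nM to 100000 nM, and a real chance that only a limit is reported.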

Compound 4, half-maximal inhibitory concentration: > 50000 nM
Compound 4 ended at the assay's limit (the forecaster's own chance of this, stated with the estimate: 55%); middle value at least 1.1-fold (0.04 log units) from the limit.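

In this assay compound 4 gives > 50000 nM, which is a limit of the assay and not a number. For the compounds shown here, the steps to compound 4 from compound 1 and from compound 2 cannot be read, and the only step that can be read is an at least 1.1-fold higher number from compound 3 to compound 4 (0.07 log units; that floor lies within the scatter). A ring carrying two chlorines thus joins the ether-bearing and sulfamoyl-bearing rings as a change on this aromatic nitrogen that shows nothing beyond the scatter, and compound 3 is the one exception to the limit that the others share: the limit of > 50000 nM in this assay, at which 3 of the 4 values shown sit.

As far as these compounds go, compounds 1, 2 and 4 have no number, so their order among themselves remains unknown. Also open, from the compounds shown here alone, is whether a phenyl ring carrying an amine or a carboxylic acid, or a longer chain in place of the ring on this nitrogen, would give a number that differs from compound 3 by more than the scatter.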